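Swapping Bromo for Methyl on a Selenium-Bearing Quinoline Ester

The source may report more compounds than this note shows. Statements on the series, on what has been measured and on what is new or still open speak of the compounds shown alone.

Among the three compounds measured so far, compound 2 `CCOC(=O)c1cc([Se]c2ccccc2)c2cc(Br)ccc2n1` stands lowest: in a functional assay on SK-MEL-147 cells (Homo sapiens) for cytotoxicity, read by MTT assay, with a stated time of 24 h (on this read-out lower numbers stand for an effect already at smaller amounts and higher numbers for an effect only at larger amounts of compound), compound 2 gives 12400 nM. Its nearest neighbour is compound 3 `CCOC(=O)c1cc([Se]Cc2ccccc2)c2cc(Br)ccc2n1`, which in this assay gives 31200 nM, the step of a 2.5-fold higher number from compound 2 to compound 3 (0.40 log units; beyond the scatter). Compound 1 `CCOC(=O)c1cc([Te]c2ccccc2)c2cc(OC)ccc2n1` differs from compound 2 in two places. In this assay compound 1 gives 128000 nM. Compound 4 `CCOC(=O)c1cc([Se]c2ccccc2)c2cc(C)ccc2n1` is the next candidate; relative to compound 2 the change is methyl in place of bromo on an aromatic carbon. Within the data shown here, no measured step touches this position, so the benzyl-for-phenyl step on selenium offers no guide, and the expectation is a step no larger than the scatter, direction uncertain. Compound 4 is therefore estimated at 18000 nM (range 5000 nM to 60000 nM), meaning an expected step of a 1.5-fold higher number from compound 2 to compound 4 (0.16 log units; within the scatter).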

Compound 4, half-maximal effective concentration: 12000 nM
Compound 4: the middle estimate sits 1.5-fold (0.18 log units) above what was measured; the range from low to high includes it.
By their numbers in this assay, from the lowest: compounds 4 and 2 (each within the scatter of the next); then compound 3; then compound 1.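

Methyl in place of bromo on an aromatic carbon gives a 1.0-fold lower number from compound 2 to compound 4 (0.01 log units; within the scatter) in this assay, so the two groups cannot be told apart on this read-out. Among these compounds, the earlier single change lay on the selenium, and this is the first reading at this position of the shared core: here, bromo is not required for a number of this size. Nothing available explains why the two groups match.

Going by these compounds, whether an amine or a carboxylic acid at this position would also leave the number in place remains open. So does the outcome for a longer chain.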